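Swapping dimethylamino for nitro on a cinnamoyl sulfonamide

This account rests on a few compounds, and the source may have more. Where it says the series, first, only, none or still open, it means among the compounds named here.

Of the compounds shown here, two of one series have been measured. Compound 1 `CN(C)c1ccc(/C=C/C(=O)NS(=O)(=O)c2ccc(F)cc2)cc1` gives 2.3 ug/mL in a functional assay on B16-F10 cells (Mus musculus) for antiproliferative activity, read by ELISA and MTT assay, with a stated time of 48 h; on this read-out lower numbers stand for stronger inhibition and higher numbers for weaker inhibition. Compound 2 `CN(C)c1ccc(/C=C/C(=O)NS(=O)(=O)c2ccc(Cl)cc2)cc1`, the same core with chloro in place of fluoro on an aromatic carbon, gives 2.8 ug/mL in this assay. Among the measured compounds shown here, the only measured step is a 1.2-fold higher number from compound 1 to compound 2 (0.09 log units; within the scatter), so the two numbers sit together and neither can be called stronger than the other.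

Compound 3 `O=C(/C=C/c1ccc([N+](=O)[O-])cc1)NS(=O)(=O)c1ccc(Cl)cc1` differs from compound 2 at the other end of the molecule: nitro in place of dimethylamino on an aromatic carbon. For the measured compounds named here, no measured step touches this position; the one known step concerns the halogen on the sulfonyl ring and says nothing about replacing dimethylamino with nitro. There is therefore no basis for expecting a step in either direction beyond the scatter, and the expectation for compound 3 simply starts from the number for compound 2, with wide uncertainty.

Compound 3 is expected to give about 3 ug/mL in this assay, within a range from 1 ug/mL to 9 ug/mL. This estimate corresponds to a step of a 1.1-fold higher number from compound 2 to compound 3 (0.03 log units; within the scatter).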

Compound 3, half-maximal inhibitory concentration: 13.7 ug/mL
Compound 3: middle estimate off by 4.6-fold (0.66 log units), on the low side, outside the stated range (above it).
By their numbers in this assay, from the lowest: compounds 1 and 2 (each within the scatter of the next); then compound 3.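

In this assay, this position, on an aromatic carbon para to a large group, proves able to move the number beyond the scatter: nitro in place of dimethylamino gives a 4.9-fold higher number from compound 2 to compound 3 (0.69 log units; beyond the scatter). The chloro and fluoro exchange gave only a 1.2-fold higher number from compound 1 to compound 2 (0.09 log units; within the scatter), so of the two changes seen, this is the only one that clearly weakens inhibition, although the step is modest and rests on a single pair of compounds. Nothing available explains why the number rises with this exchange of groups.

One pair cannot show whether dimethylamino helps, nitro hurts, or both, and a plain hydrogen, a methoxy group or a simple amine at the same position would help to separate these possibilities. As far as these compounds go, it also remains open whether nitro in place of dimethylamino would produce a step of similar size when the halogen is fluoro rather than chloro, or when a larger group such as trifluoromethyl takes the halogen's place.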